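The source may hold more compounds than are shown below. What is called first, only, known or untested is meant among the compounds shown, and "the series" means these compounds.

Measured so far:
compound 1, `COc1cc(OC)c(NC(=O)Cn2nc(CC(=O)O)c3ccccc32)cc1Cl`: 1.86
compound 2, `C[C@@H](C(=O)O)c1nn(Cc2cn3cc(OCC4CC4)c(Cl)cc3n2)c2ccccc2c1=O`: 2.41
compound 3, `COc1cc(OC)c(NC(=O)Cc2nn(CC(=O)O)c(=O)c3ccccc23)cc1Cl`: 1.64

Of the three compounds measured in a physicochemical assay for lipophilicity, at pH 7.4 (a higher number here means a more lipophilic compound, a lower number a more polar compound), compound 2 stands highest. Its nearest neighbour is compound 1, whose number lies lower by a gap beyond the scatter, and compound 3 lies lower still, again beyond the scatter. None of these three pairs differs in a single place, so the account does not trace any measured step between them; it only records where compound 2 stands.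

Compound 4, `O=C(O)Cc1nn(Cc2cn3cc(OCC4CC4)c(Cl)cc3n2)c2ccccc2c1=O`, has not yet been measured in this assay. It differs from compound 2 in one place: hydrogen in place of methyl on a saturated chain carbon bound to an aromatic carbon and a carbonyl carbon. A carbon is lost from the chain and nothing takes its place beyond a hydrogen. Among the measured compounds shown here, with no measured step of this kind among the three compounds, the expectation rests on the change itself: a small fall in this assay, probably at or just beyond the scatter, rather than a rise. Compound 4 is therefore expected to give 2, with a range from 1.6 to 2.4. The estimated step of a number 0.41 log units lower from compound 2 to compound 4 (beyond the scatter) is a modest drop.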

Compound 4, distribution coefficient: 2.13
The estimate for compound 4 lay 0.13 log units below the measured number; measured number inside the range.
By their numbers in this assay, from the lowest: compounds 3, 1, 4 and 2 (each within the scatter of the next, the first and the last beyond it).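

Among the compounds shown here, at this position, the first step that can be read in this assay is a number 0.28 log units lower from compound 2 to compound 4 (within the scatter), for hydrogen in place of methyl on a saturated chain carbon bound to an aromatic carbon and a carbonyl carbon. For the compounds shown here, the three earlier compounds offered no such pair, and this one shows that going from 1-carboxyethyl to carboxymethyl on this core does not separate compound 2 and compound 4 beyond the scatter. Nothing is at hand that would explain this step.

The compounds shown leave open whether a longer chain, a second methyl or an amine on that same chain carbon would give a step beyond the scatter. Going by these compounds alone, they also leave open whether hydrogen in place of methyl would read the same way on a core other than the one shared by compound 2 and compound 4.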